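The compounds below may be only part of what the source reports. "The series", "measured", "known", "first", "only" and "open" are said of these compounds alone.

Compound 1 `N#Cc1c(-c2cccc(F)c2)c(C#N)c(=O)n(/N=C/c2cn(-c3ccccc3)nc2-c2ccccc2)c1N` and compound 2 `Cc1ccc(-c2c(C#N)c(N)n(/N=C/c3cn(-c4ccccc4)nc3-c3ccccc3)c(=O)c2C#N)cc1` share one core and differ only in the aryl group attached to it. In an ADME assay on HeLa cells (Homo sapiens) for cytotoxicity, read by MTT assay (on this read-out higher numbers stand for weaker inhibition and lower numbers for stronger inhibition), compound 1 gives > 200 ug/mL, which is a limit of the assay, not a number. Compound 2 gives > 200 ug/mL in this assay, likewise a limit. The step that the two limits leave unreadable from compound 1 to compound 2 therefore has no readable size, and the limit of > 200 ug/mL in this assay, at which 2 of the 2 values shown sit, is all the measured material offers. Compound 3 `COc1cc(-c2c(C#N)c(N)n(/N=C/c3cn(-c4ccccc4)nc3-c3ccccc3)c(=O)c2C#N)cc(OC)c1OC` carries 3,4,5-trimethoxyphenyl in place of 4-methylphenyl on an aromatic carbon. For the measured compounds named here, no measured step bears directly on this change, and the single measured step left both values at the limit. Compound 3 is therefore expected to sit close to that limit as well, the step that the limit leaves unreadable from compound 2 to compound 3 being estimated as none beyond the scatter. The estimate for compound 3 is 250 ug/mL, expected between 120 ug/mL and 600 ug/mL.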

Compound 3, half-maximal inhibitory concentration: > 200 ug/mL
Compound 3 was reported as a limit (the forecaster's own chance of this, stated with the estimate: 85%); the middle value does not contradict the limit.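

Compound 3 also gives only a limit, so no step among compound 1, compound 2 and compound 3 can be read: the limit of > 200 ug/mL in this assay, at which 3 of the 3 values shown sit.
Where these compounds truly stand on this read-out stays open, as does whether any aryl change on the shared core would shift it.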